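Amide variation at the aminomethyl side chain

The compounds below may be only part of what the source reports. "The series", "measured", "known", "first", "only" and "open" are said of these compounds alone.

Measured so far:
compound 1 `CCCCc1ccc(CN)c(=O)n1Cc1ccc(-c2ccccc2-c2nn[nH]n2)cc1`: 20 nM
compound 2 `CCCCc1ccc(CNC(=O)N(C)C)c(=O)n1Cc1ccc(-c2ccccc2-c2nn[nH]n2)cc1`: 2 nM

In a functional assay (aorta) for antagonist activity, with Oryctolagus cuniculus as the target (a higher number here means a weaker inhibitor, a lower number a stronger inhibitor), compound 2 gives 2 nM, the lowest of the two numbers, and compound 1 is the only other point. Within the data shown here, the single measured step, a 10-fold lower number from compound 1 to compound 2 (1.00 log units; beyond the scatter), shows that placing a carbonyl-bearing group on that amine nitrogen lowers the number well beyond the scatter.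

Compound 3 `CCCCc1ccc(CNC(C)=O)c(=O)n1Cc1ccc(-c2ccccc2-c2nn[nH]n2)cc1` differs from compound 2 by methyl in place of dimethylamino on a carbonyl carbon. Compound 3 keeps a carbonyl on the amide-type nitrogen, so the feature gained in a 10-fold lower number from compound 1 to compound 2 (1.00 log units; beyond the scatter) is retained; what is not known is whether the dimethylamino part of compound 2 itself contributes. The expectation for compound 3 is therefore a number close to compound 2, with the step of a 2.0-fold higher number from compound 2 to compound 3 (0.30 log units; within the scatter) expected to stay within or just beyond the scatter, most likely toward a slightly higher number. Compound 3 is estimated at 4 nM in this assay, with a range of 1.5 nM to 12 nM.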

Compound 3, half-maximal inhibitory concentration: 3 nM
Compound 3: the middle estimate sits 1.3-fold (0.12 log units) above what was measured; the measured number falls inside the stated range.
By their numbers in this assay, from the lowest: compounds 2 and 3 (each within the scatter of the next); then compound 1.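

In this assay the step of a 1.5-fold higher number from compound 2 to compound 3 (0.18 log units; within the scatter) stays within the scatter, so methyl in place of dimethylamino on a carbonyl carbon gives no readable difference at this position. The step of a 6.7-fold lower number from compound 1 to compound 3 (0.82 log units; beyond the scatter) lies beyond the scatter, which shows that the drop seen with dimethylcarbamoyl on the amine nitrogen does not need the dimethylamino part, since acetyl gives it as well. No measured evidence bears on why these two carbonyl-bearing groups read alike.

Still open, from the compounds shown here alone, is how far this tolerance extends on the carbonyl carbon, for example to a longer chain as in butanoyl, or to a phenyl ring as in benzoyl. Also open, going by these compounds, is whether the carbonyl itself is needed, which a methanesulfonyl group on the same nitrogen would test.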